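From Acetoxy to Acetoxymethyl on the Sulfonyl Chain

This account rests on a few compounds, and the source may have more. Where it says the series, first, only, none or still open, it means among the compounds named here.

In a physicochemical assay for solubility, at pH 7.4 (a higher number here means a more soluble compound, a lower number a less soluble compound), compound 1 `Nc1cc(S(N)(=O)=O)ccc1S(=O)(=O)CCCO` gives 8400 ug/mL and compound 2 `CC(=O)OCCS(=O)(=O)c1ccc(S(N)(=O)=O)s1` gives 880 ug/mL as the lower of the two numbers, a gap that lies beyond the scatter. Within the data shown here, these two compounds do not differ in one place only, and no measured step for a single change is available. Compound 3 `CC(=O)OCCCS(=O)(=O)c1ccc(S(N)(=O)=O)s1` has not yet been measured. It departs from compound 2 by acetoxymethyl in place of acetoxy on a saturated chain carbon, two bonds along the chain from a sulfonyl sulfur with acetoxymethyl in place of acetoxy on a saturated chain carbon, two bonds along the chain from a sulfonyl sulfur. Among the measured compounds shown here, with no measured step to go by, only a small drop that stays within the scatter is expected, and the estimated 1.5-fold lower number from compound 2 to compound 3 (0.17 log units; within the scatter) in this assay is of that size. For compound 3 the expected value is 600 ug/mL with an estimated range from 250 ug/mL to 1300 ug/mL in this measurement.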

Compound 3, solubility: 920 ug/mL
Compound 3: the middle estimate sits 1.5-fold (0.19 log units) below what was measured; measured number inside the range.
By their numbers in this assay, from the lowest: compounds 2 and 3 (each within the scatter of the next); then compound 1.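

In this assay, replacing acetoxy with acetoxymethyl on a saturated chain carbon, two bonds along the chain from a sulfonyl sulfur, gives a 1.0-fold higher number from compound 2 to compound 3 (0.02 log units; within the scatter). Among these compounds, this is the first reading of a change in one place, since compound 1 and compound 2 differ in more than one place and could not speak for this position; here, the longer acetoxymethyl group leaves the read-out within the scatter on the shared core. No supporting measurement is available to explain this result.

Going by these compounds, whether an amine or a carboxylic acid at the end of the chain, or a longer chain, would stay equally close to compound 2 remains open. On these data alone, it is also open whether the same change would read the same way on the core of compound 1.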